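Amide aryl variation: from compound 3 to compound 4

This account rests on a few compounds, and the source may have more. Where it says the series, first, only, none or still open, it means among the compounds named here.

Three measured compounds share one core and differ only in the aryl group on the amide nitrogen. Compound 1 `O=C(COc1ccc2cc(/C=C3/SC(=O)NC3=O)ccc2c1)Nc1ccc(Br)cc1F` carries a 4-bromo-2-fluorophenyl there. In an assay on isolated protein for inhibition of histone deacetylase 8 (Homo sapiens), with a stated time of 1 h (a lower number here means a stronger inhibitor, a higher number a weaker inhibitor), compound 1 reaches only a limit of the assay, > 50000 nM, and no number. Compound 2 `O=C(COc1ccc2cc(/C=C3/SC(=O)NC3=O)ccc2c1)Nc1ccc(F)cc1` carries a 4-fluorophenyl and gives 6600 nM in this assay. Compound 3 `O=C(COc1ccc2cc(/C=C3/SC(=O)NC3=O)ccc2c1)Nc1ccc(Cl)c(Cl)c1` carries a 3,4-dichlorophenyl. In this assay compound 3 stands at a limit, > 50000 nM, not at a number. The measured steps are an at least 7.5-fold lower number from compound 1 to compound 2 (0.87 log units; beyond the scatter) and an at least 7.5-fold higher number from compound 2 to compound 3 (0.87 log units; beyond the scatter); the third, a step that the two limits leave unreadable from compound 1 to compound 3, cannot be read because of the limit of > 50000 nM in this assay, at which 2 of the 3 values shown sit.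

Compound 4 `O=C(COc1ccc2cc(/C=C3/SC(=O)NC3=O)ccc2c1)Nc1c(F)cc(F)cc1Br` is reached by the change (2-bromo-4,6-difluorophenyl in place of 3,4-dichlorophenyl on an amide-type nitrogen). For the measured compounds named here, no measured step matches this exchange directly. Going by the values given here, what bears on it: the two compounds with more than one halogen on the aryl group, compound 1 and compound 3, both sit at the limit, and the only value below the limit in this assay belongs to compound 2. In this assay no step beyond the scatter is therefore expected, and the step of a number no higher from compound 3 to compound 4 (the limit leaves the size open) is estimated to keep compound 4 at or near the limit. Compound 4 is expected at 50000 nM, within 10000 nM to 200000 nM, and most likely reported only as a limit.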

Compound 4, half-maximal inhibitory concentration: > 50000 nM
Compound 4: a limit, no number (the forecaster's own chance of this, stated with the estimate: 65%); the middle value lies on the limit itself.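

For the compounds shown here, the one readable new step is an at least 7.5-fold higher number from compound 2 to compound 4 (0.87 log units; beyond the scatter). Going by these compounds alone, on the amide-type nitrogen, a third aryl group with more than one halogen, 2-bromo-4,6-difluorophenyl, thus joins compound 1 and compound 3 at the limit, while compound 2, with the single halogen of its 4-fluorophenyl, remains the only one of the four compounds with a number; none of the four goes against this pattern, which reaches no further than these compounds. The steps from compound 3 to compound 4 and from compound 1 to compound 4 cannot be read, because of the following: the limit of > 50000 nM in this assay, at which 3 of the 4 values shown sit.

With a single number in this assay, the compounds shown give no ranking among the aryl groups with more than one halogen, and they do not separate the count of halogens from their kind or their place on the ring. Also open, as far as these compounds go, is how an unsubstituted phenyl, a 4-methoxyphenyl or a 4-aminophenyl on the amide-type nitrogen would read in this assay, and whether any of them would give a number rather than a limit.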